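A few compounds are considered here, and "the series" means these few. Any claim that something is new, unique, unknown or untested is made for them only; others in the source may bear on it.

Measured compounds: compound 1 `CCCc1ccc(NC2=CC(=O)c3nc4n(c3C2=O)[C@H]2OC[C@@H](O)[C@H]2OC4)cc1` gives 4660 nM in a functional assay on MCF7 cells (Homo sapiens) for inhibition, read by sulforhodamine B assay; a lower number here means a stronger inhibitor, a higher number a weaker inhibitor; compound 3 `Cc1ccc(NC2=CC(=O)c3nc4n(c3C2=O)[C@H]2OC[C@@H](O)[C@H]2OC4)cc1C` gives 2080 nM. Compound 2 `O=C1C(NC2CCCC2)=CC(=O)c2c1nc1n2[C@H]2OC[C@@H](O)[C@H]2OC1` gives only a limit, > 16000 nM, in this assay.

Compound 2 therefore stands at the limit of > 16000 nM in this assay, at which 1 of the 3 values shown sits, and has no number of its own. Compound 4 `CCCc1ccc(NC2=CC(=O)c3c(nc4n3[C@H]3OC[C@@H](O)[C@H]3OC4)C2=O)cc1` differs from it by 4-propylphenyl in place of cyclopentyl on an amine nitrogen. Within the data shown here, the one measured step, a 2.2-fold lower number from compound 1 to compound 3 (0.35 log units; beyond the scatter), exchanges one aryl group for another and does not touch this change. Compound 1 and compound 3 both carry aryl groups on the amine nitrogen and both give numbers, while compound 2 carries cyclopentyl and gives a limit. Compound 4 is therefore expected to show an at least 3.2-fold lower number from compound 2 to compound 4 (0.50 log units; beyond the scatter), toward a stronger inhibitor. Compound 4 is estimated at 5000 nM, between 1500 nM and 16000 nM.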

Compound 4, half-maximal inhibitory concentration: > 4000 nM
Compound 4: a limit, no number; the forecaster's own chance of this, stated with the estimate: 15%; the middle value lies beyond the limit too.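

Compound 2 and compound 4 both give only limits, so the step between them cannot be read. The compounds shown leave open whether 4-propylphenyl in place of cyclopentyl on an amine nitrogen changes the number in this assay at all.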